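Series notes: amine swap, expected tolerated concentration

The source may hold more compounds than are shown below. What is called first, only, known or untested is meant among the compounds shown, and "the series" means these compounds.

Compound 1 `CCCN(CCC)c1ccc(NC(=O)c2cc(Cl)ccc2O)c(Cl)c1` gives 323000 nM in an ADME assay on A549 cells (Homo sapiens) for cytotoxicity, read by LDH release, with a stated time of 15 h; a higher number here means that more compound is tolerated, a lower number that less compound is tolerated. Among the compounds with values here, compound 2 `O=C(Nc1ccc(N2CCCC2)cc1Cl)c1cc(Cl)ccc1O` gives "not determined" (no result reported) in this assay, so it stands nowhere on the measured scale, and no step from it to any neighbour can be counted. Compound 3 `CC1(Nc2ccc(NC(=O)c3cc(Cl)ccc3O)c(Cl)c2)CCCCC1` differs from compound 2 by (1-methylcyclohexyl)amino in place of pyrrolidin-1-yl on an aromatic carbon. Within the data shown here, with no measured step available, the expectation for compound 3 in this assay is a change that stays within the usual scatter, in neither direction beyond it, with the reading of compound 1 as the only anchor. Compound 3 is therefore estimated at 200000 nM, within a range of 50000 nM to 500000 nM.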

Compound 3, half-maximal cytotoxic concentration: 86500 nM
Beside the measured number, compound 3's estimate is 2.3-fold (0.36 log units) above it; measured number inside the range.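

In this assay, within the data shown here, the aromatic carbon carrying the amine proves sensitive to the choice of amine: (1-methylcyclohexyl)amino in place of dipropylamino gives a 3.7-fold lower number from compound 1 to compound 3 (0.57 log units; beyond the scatter) and this is the first readable step at this position. Steps involving compound 2 cannot be read, so pyrrolidin-1-yl stays outside the comparison. Nothing available accounts for the step.

Open, going by these compounds, is whether the lower number goes with the six-membered carbon ring or with the hydrogen-bond donor that enters with it. Also open, on these data alone, is how a morpholin-4-yl group or a dibutylamino group would read on this carbon.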